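The source may report more compounds than this note shows. Statements on the series, on what has been measured and on what is new or still open speak of the compounds shown alone.

Working notes on the series. Within the data shown here, in a functional assay on A-375 cells (Homo sapiens) for antiproliferative activity, read by CCK-8 assay, with a stated time of 72 h (a lower number here means a stronger inhibitor, a higher number a weaker inhibitor), compound 1 (`Nc1ccccc1NC(=O)c1ccc(Cn2cnc3c(Nc4ccccc4)nc(Cl)nc32)cc1`) gives 2800 nM and compound 2 (`CC(C)n1cnc2c(NCc3ccc(C(=O)Nc4ccccc4N)cc3)nc(Cl)nc21`) gives 2170 nM and no two measured compounds differ in one place only. Compound 3 (`Nc1ccccc1NC(=O)c1ccc(COCNc2nc(Nc3ccccc3)c3ncn(C4CCCC4)c3n2)cc1`) stands highest at 8700 nM and is the weakest of the three, beyond the scatter from both compound 1 and compound 2. Compound 4 (`CCCCn1cnc2c(Nc3ccccc3)nc(NCOCc3ccc(C(=O)Nc4ccccc4N)cc3)nc21`) is unmeasured and carries butyl in place of cyclopentyl on an aromatic nitrogen relative to compound 3. Among the measured compounds shown here, the data hold no direct precedent for this change. The expected change in this assay lies within the scatter, with an estimated step (a 1.2-fold lower number from compound 3 to compound 4 (0.09 log units; within the scatter)) toward a slightly lower number. Compound 4 is estimated at 7000 nM (expected range 3000 nM to 16000 nM).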

Compound 4, half-maximal inhibitory concentration: 4480 nM
Compound 4: the middle estimate sits 1.6-fold (0.19 log units) above what was measured, within the range that was stated.
By their numbers in this assay, from the lowest: compounds 2, 1, 4 and 3 (each within the scatter of the next, the first and the last beyond it).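

In this assay, among these compounds, the step for butyl in place of cyclopentyl on an aromatic nitrogen, a 1.9-fold lower number from compound 3 to compound 4 (0.29 log units; within the scatter), is the first single-place comparison. On this one pair, the five-membered carbon ring and the open butyl chain cannot be told apart at this position. No evidence on hand accounts for the size of this step. Still open, from the compounds shown here alone, is how a longer chain such as hexyl, or a butyl chain ending in an amine, would read at this nitrogen. Going by these compounds, a ring of another size, such as cyclohexyl, remains equally open.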